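The compounds below may be only part of what the source reports. "The series", "measured", "known", "first", "only" and "open" are said of these compounds alone.

In a functional assay on MCF7 cells (Homo sapiens) for antiproliferative activity, read by MTT assay, with a stated time of 72 h (a lower number here means a stronger inhibitor, a higher number a weaker inhibitor), compound 1 `CC1=CC[C@H]2[C@@H]1CC=C(C)[C@@H](CC[C@H]1[C@]3(C)CC[C@H](OC(=O)c4ccncc4)C(C)(C)O[C@H]3CC[C@@]1(C)O)C2(C)C` reaches only a limit of the measurement, > 50000 nM. Compound 2 `CC1=C(CC[C@H]2[C@]3(C)CC[C@H](O)C(C)(C)O[C@H]3CC[C@@]2(C)O)[C@](C)(C/C=C/C(C)(C)OO)[C@H](O)CC1` gives 27400 nM in this assay. Compound 3 `CC1(C)O[C@H]2CC[C@@](C)(O)[C@@H](CC[C@@H]3C(CO)=CC[C@H]4[C@H](CC[C@]4(C)O)C3(C)C)[C@]2(C)CC[C@@H]1O` also stands only at a limit in this assay, namely > 50000 nM. Two of the three values thus sit at the limit of > 50000 nM in this assay, at which 2 of the 3 values shown sit, and no number places compound 3 among the others. Compound 4 `CC1(C)O[C@H]2CC[C@@](C)(O)[C@@H](CC[C@@H]3C(C=O)=CC[C@H]4[C@H](CC[C@]4(C)O)C3(C)C)[C@]2(C)CC[C@@H]1O` differs from compound 3 by formyl in place of hydroxymethyl on a double-bonded ring carbon. Going by the values given here, no measured pair here differs in a single place, so the size of such a step cannot be drawn from the data. The expected step is an at least 1.1-fold lower number from compound 3 to compound 4 (0.04 log units; that floor lies within the scatter), none beyond the scatter. Compound 4 is therefore estimated at 45000 nM in this assay, within 15000 nM to 150000 nM.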

Compound 4, half-maximal inhibitory concentration: > 50000 nM
Compound 4 gave a limit, no number (the forecaster's own chance of this, stated with the estimate: 60%); middle value at least 1.1-fold (0.04 log units) away from the limit.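

Compound 3 and compound 4 each stand only at a limit, so formyl in place of hydroxymethyl gives no readable step: the limit of > 50000 nM in this assay, at which 3 of the 4 values shown sit.

The compounds shown leave open whether this change alters antiproliferative activity at all.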